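Shortening an alkynyl chain in a small antiproliferative series

The source may report more compounds than this note shows. Statements on the series, on what has been measured and on what is new or still open speak of the compounds shown alone.

Measured compounds:
Compound 1, `O=C1c2ccccc2C(=O)N1C/C=C\Cn1cc(C#Cc2ccc(Br)cc2)c(=O)[nH]c1=O`, gives > 100000 nM in a functional assay on MCF7 cells (Homo sapiens) for antiproliferative activity, read by MTT assay, with a stated time of 3 days; on this read-out lower numbers stand for stronger inhibition and higher numbers for weaker inhibition; this value is a limit of the assay, not a number.
Compound 2, `CCCCCC#Cc1cn(C/C=C/CN2C(=O)c3ccccc3C2=O)c(=O)[nH]c1=O`, gives 44000 nM in this assay.
Compound 3, `O=C1c2ccccc2C(=O)N1C/C=C\Cn1cc(C#CCCc2ccccc2)c(=O)[nH]c1=O`, gives > 100000 nM in this assay; this value too is a limit.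

Going by the values given here, compound 2 therefore stands alone as the only compound with a measured number, while the other two sit at the limit of > 100000 nM in this assay, at which 2 of the 3 values shown sit. Among the compounds with values here, the single measured step, a step that the two limits leave unreadable from compound 1 to compound 3, exchanges one whole end group for another, and its size cannot be read from two limits.

Compound 4, `CCCCC#Cc1cn(C/C=C/CN2C(=O)c3ccccc3C2=O)c(=O)[nH]c1=O`, differs from compound 2 by hydrogen in place of methyl on a saturated chain carbon, four bonds along the chain from a triple-bonded carbon. Within the data shown here, no measured step concerns a change of this kind, so nothing in the data points to a large shift in either direction, and the working expectation is a step within the usual scatter.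

Compound 4 is thus estimated to give 50000 nM in this assay, with a range from 20000 nM to 100000 nM. This estimate corresponds to an expected step of a 1.1-fold higher number from compound 2 to compound 4 (0.06 log units; within the scatter).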

Compound 4, half-maximal inhibitory concentration: 8800 nM
Compound 4: middle estimate off by 5.7-fold (0.75 log units), on the high side; measured number outside the range, below it.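

Even a change as small as hydrogen in place of methyl, on a saturated chain carbon, four bonds along the chain from a triple-bonded carbon, matters at this position: in this assay it gives a 5.0-fold lower number from compound 2 to compound 4 (0.70 log units; beyond the scatter). The far end of this alkyl chain is therefore not a silent part of the molecule, and lower numbers here stand for stronger inhibition. Compound 1 and compound 3 each carry only a limit of the assay, not a number, and the step between them cannot be read, so they add no size to compare: the limit of > 100000 nM in this assay, at which 2 of the 4 values shown sit.

As far as these compounds go, one pair does not make a trend, so it remains open whether a still shorter propyl or ethyl chain would bring the number down further. Equally open, from the compounds shown here alone, is how a hydroxyl group or an amine at the chain end would behave.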